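Amide variation on the aryloxy chain of the benzofuran-ketone series

The compounds below may be only part of what the source reports. "The series", "measured", "known", "first", "only" and "open" are said of these compounds alone.

Within the data shown here, compound 2 `CCCCc1oc2ccccc2c1C(=O)c1ccc(OCCCC(=O)N2CCCC2)cc1` is the only member with a number in a functional assay on MDA-MB-231 cells (Homo sapiens) for antiproliferative activity, read by MTT assay, with a stated time of 24 h (on this read-out lower numbers stand for stronger inhibition and higher numbers for weaker inhibition), where compound 2 gives 48700 nM. Compound 1 `CCCCc1oc2ccccc2c1C(=O)c1ccc(OCC(=O)N2CCCCC2)cc1` in this assay gives > 50000 nM, which is a limit of the assay and not a number, as marked by the limit of > 50000 nM in this assay, at which 1 of the 2 values shown sits. Among the measured compounds shown here, the step of an at least 1.0-fold lower number from compound 1 to compound 2 (0.01 log units; that floor lies within the scatter) is the single measured comparison, and it lies within the scatter, so the series so far shows no change beyond scatter.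

Compound 3 `CCCCc1oc2ccccc2c1C(=O)c1ccc(OCCCC(=O)NCc2ccccc2)cc1` differs from compound 2 by benzylamino in place of pyrrolidin-1-yl on a carbonyl carbon. For the measured compounds named here, no measured step touches the amide nitrogen substituent; the one measured step concerns the chain length and the ring on the amide, and it was flat. Going by the values given here, the change to compound 3 therefore has no direct precedent, and the expectation rests on the flatness seen so far: no step beyond the scatter in this assay is expected for compound 3, with a 1.2-fold lower number from compound 2 to compound 3 (0.09 log units; within the scatter) as the expected step. For compound 3 the estimate in this assay is 40000 nM, with a range from 15000 nM to 100000 nM, and a substantial chance that only a limit is reported.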

Compound 3, half-maximal inhibitory concentration: > 50000 nM
Compound 3 gave a limit, no number; the forecaster's own chance of this, stated with the estimate: 45%; middle value at least 1.2-fold (0.09 log units) from the limit.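

In this assay compound 3 gives > 50000 nM, which is a limit of the assay and not a number. The step reads as an at least 1.0-fold higher number from compound 2 to compound 3 (0.01 log units; that floor lies within the scatter); this is the only step shown that changes the group on the carbonyl carbon while the chain stays the same, and benzylamino in place of pyrrolidin-1-yl, which brings in an aromatic ring and an amide hydrogen, gives no change beyond the scatter, although only the floor of the step can be read and its full size stays unknown. With this result, values at the limit make up most of the series, and the flat picture now extends from the chain and amide ring change to the amide nitrogen substituent, with compound 2 still the only number: the limit of > 50000 nM in this assay, at which 2 of the 3 values shown sit.

The compounds shown leave open whether a morpholin-4-yl or 4-methylpiperazin-1-yl group on this carbonyl carbon, or a carboxylic acid in place of the amide, would give a number clearly lower than that of compound 2. They also leave open whether a longer chain on the aromatic ring's oxygen, with benzylamino kept, would give a number at all.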